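Chloro entering compound 3 at the place vacated by nitro

A few compounds are considered here, and "the series" means these few. Any claim that something is new, unique, unknown or untested is made for them only; others in the source may bear on it.

Measured so far in a functional assay on the whole organism (strain Swiss albino) with Mus musculus as the target, in the maximal electroshock model; on this read-out lower numbers stand for an effect already at smaller amounts and higher numbers for an effect only at larger amounts of compound:
compound 1 `O=[N+]([O-])c1ccc(/C=N/Cc2cccnc2)cc1` gives 61.4 mg/kg
compound 2 `Clc1ccccc1/C=N/Cc1cccnc1` gives 11.7 mg/kg
compound 3 `C(=N/Cc1cccnc1)\c1ccccc1` gives 53 mg/kg

Compound 3 stands second highest of the three numbers. Its nearest neighbour is compound 1, a step that is within the scatter: a 1.2-fold lower number from compound 1 to compound 3 (0.06 log units; within the scatter). Its furthest is compound 2, beyond the scatter: a 4.5-fold higher number from compound 2 to compound 3 (0.66 log units; beyond the scatter).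

Compound 4 is `Clc1ccc(/C=N/Cc2cccnc2)cc1`. It differs from compound 3 by chloro in place of hydrogen on an aromatic carbon, placed on an aromatic carbon of a six-membered aromatic ring of carbon only, para to a group of 9 heavy atoms.

Among the compounds with values here, two measured steps bear on this. The chloro of compound 2 does not sit at the place described for compound 4, so the step from compound 2 to compound 3 tells only that a chloro on this ring can lower the number modestly. The nitro of compound 1 sits at that very place, and its loss changed nothing beyond the scatter. The expectation for compound 4 in this assay is therefore a modest lowering at most, a 1.8-fold lower number from compound 3 to compound 4 (0.25 log units; within the scatter), estimated at 30 mg/kg with a range of 12 mg/kg to 70 mg/kg.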

Compound 4, dose for half-maximal effect: 53 mg/kg
Compound 4: the middle estimate sits 1.8-fold (0.25 log units) below what was measured; low and high end bracket the measured number.
By their numbers in this assay, from the lowest: compound 2; then compounds 3, 4 and 1 (each within the scatter of the next).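

At this place on the aromatic ring, para to a group of 9 heavy atoms, chloro in place of hydrogen leaves the number in this assay where it was, with no change at the digits printed from compound 3 to compound 4 (within the scatter). Chloro in place of nitro at the same carbon gives a 1.2-fold lower number from compound 1 to compound 4 (0.06 log units; within the scatter), so hydrogen, nitro and chloro at this place cannot be told apart on this read-out, whereas the earlier compounds offered only the single comparison of nitro with hydrogen here. The lower number seen with a chloro on this ring therefore does not carry over to this place, since compound 2, with its chloro elsewhere on the ring, gives 11.7 mg/kg and compound 4 gives 53 mg/kg, and no supporting data bear on this difference.

Still open, on these data alone, is whether a group of another kind at this place, such as an amine, a carboxylic acid or a longer alkyl chain, would move the number beyond the scatter. The compounds shown also leave open whether other groups at the place occupied by the chloro of compound 2 would give a number as low as that of compound 2.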